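The compounds below may be only part of what the source reports. "The series", "measured", "known", "first", "only" and "open" are said of these compounds alone.

Measured in an assay on isolated protein for inhibition of matrix metalloproteinase-9 (Homo sapiens); a higher number here means a weaker inhibitor, a lower number a stronger inhibitor:
compound 1 `CCCS(=O)(=O)N(C[C@H](O)C(=O)NO)c1ccc(Oc2ccc(C)cc2)cc1`, 124 nM
compound 2 `Cc1ccc(Oc2ccc(N(C[C@H](O)C(=O)NO)S(=O)(=O)C(C)C)cc2)cc1`, 286 nM
compound 3 `Cc1ccc(Oc2ccc(N(C[C@H](O)C(=O)NO)S(=O)(=O)Cc3cccnc3)cc2)cc1`, 69 nM

Compound 3 has the lowest of the three numbers in this assay, but its gap to compound 1 is within the scatter, so those two cannot be ranked against each other; only compound 2 stands clearly apart, shown by a 4.1-fold lower number from compound 2 to compound 3 (0.62 log units; beyond the scatter). Compound 4 `Cc1ccc(Oc2ccc(N(C[C@H](O)C(=O)NO)S(=O)(=O)N(C)C)cc2)cc1` differs from compound 3 in one place: dimethylamino in place of (pyridin-3-yl)methyl on a sulfonyl sulfur. Within the data shown here, no measured step makes exactly this exchange. The comparisons that bear on it are the ones that swap the group on the sulfonyl sulfur: a 4.1-fold lower number from compound 2 to compound 3 (0.62 log units; beyond the scatter), a 1.8-fold lower number from compound 1 to compound 3 (0.25 log units; within the scatter) and a 2.3-fold higher number from compound 1 to compound 2 (0.36 log units; beyond the scatter). Both groups without a ring on that sulfur gave higher numbers than the (pyridin-3-yl)methyl group, and dimethylamino likewise brings no ring, so for compound 4 a rise in the number is expected, a 2.9-fold higher number from compound 3 to compound 4 (0.46 log units; beyond the scatter). Compound 4 is therefore estimated at 200 nM in this assay, with a range from 80 nM to 500 nM.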

Compound 4, half-maximal inhibitory concentration: 243 nM
Compound 4: middle estimate off by 1.2-fold (0.08 log units), on the low side; the range from low to high includes it.
By their numbers in this assay, from the lowest: compounds 3, 1, 4 and 2 (each within the scatter of the next, the first and the last beyond it).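

In this assay, dimethylamino, which joins the sulfonyl sulfur through nitrogen, falls in with the carbon-linked groups that have no ring: it stands clearly apart from (pyridin-3-yl)methyl (a 3.5-fold higher number from compound 3 to compound 4 (0.55 log units; beyond the scatter)) but cannot be told from isopropyl (a 1.2-fold lower number from compound 2 to compound 4 (0.07 log units; within the scatter)) or propyl (a 2.0-fold higher number from compound 1 to compound 4 (0.29 log units; within the scatter)). Among these three groups without a ring, then, a nitrogen or a carbon on the sulfur makes no readable difference, and compound 3 is clearly separated from compound 2 and compound 4, while compound 1 goes against that pattern, with its gap to compound 3 within the scatter. Nothing measured here accounts for these numbers.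

As far as these compounds go, whether the ring itself or its nitrogen goes with the lower number stays open: a benzyl group, with a benzene ring in place of the pyridine, would separate the two. A cyclic amine such as piperidine on the sulfur would show whether a ring still lowers the number when nitrogen is the attached atom.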